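This account rests on a few compounds, and the source may have more. Where it says the series, first, only, none or still open, it means among the compounds named here.

- Compound 1 `COc1ccc(/C=C/C(=O)c2cccc(-c3ccc(F)cc3)c2)cc1`: 11200 nM
- Compound 2 `COc1ccc(/C=C/C(=O)c2ccc(N)c(-c3ccc(F)cc3)c2)cc1OC`: 8630 nM

In a functional assay on A549 cells (Homo sapiens) for cytotoxicity, read by sulforhodamine B assay, with a stated time of 48 h (a lower number here means a stronger inhibitor, a higher number a weaker inhibitor), compound 2 gives 8630 nM and compound 1 gives 11200 nM. These two values lie within the usual scatter of each other, so they cannot be told apart.

Compound 3 `COc1ccc(/C=C/C(=O)c2cccc(-c3ccc(F)cc3)c2)cc1OC` has not yet been measured. It has hydrogen in place of amino on an aromatic carbon, ortho to a 4-fluorophenyl group and para to a large group (hydrogen in place of amino on an aromatic carbon). Within the data shown here, no measured pair shows this change alone. Compound 1 also carries hydrogen at this place and gives 11200 nM, though it differs from compound 3 elsewhere as well. On that basis, no change beyond the scatter is expected, and the estimated step is a 1.2-fold higher number from compound 2 to compound 3 (0.06 log units; within the scatter). The estimate for compound 3 is 10000 nM, with an expected range from 4000 nM to 25000 nM.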

Compound 3, half-maximal inhibitory concentration: 11800 nM
Estimate against measurement, compound 3: 1.2-fold (0.07 log units) below; low and high end bracket the measured number.
By their numbers in this assay, from the lowest: compounds 2, 1 and 3 (each within the scatter of the next).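

In this assay, compound 2 and compound 3 differ only at the aromatic carbon ortho to a 4-fluorophenyl group, and hydrogen in place of amino there gives a 1.4-fold higher number from compound 2 to compound 3 (0.14 log units; within the scatter) in this pair, so the assay cannot tell these two groups apart at this position. Compound 1 and compound 3 now also form a pair, and methoxy in place of hydrogen on an aromatic carbon gives a 1.1-fold higher number from compound 1 to compound 3 (0.02 log units; within the scatter) in that comparison, so this change cannot be told from no change either. Nothing measured here gives a reason for these results.

On these data alone, it remains open whether a carboxylic acid or an acetamide on the carbon that carries the amino group in compound 2 would shift the number beyond the scatter. The same question stands for a hydroxy group in place of the methoxy group that separates compound 3 from compound 1.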